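The source may hold more compounds than are shown below. What is called first, only, known or untested is meant among the compounds shown, and "the series" means these compounds.

Measured so far in an assay on CHO cells for displacement of a labelled ligand from muscarinic acetylcholine receptor M5 (Homo sapiens), read by scintillation counting, with a stated time of 2 h; a lower number here means a stronger inhibitor, a higher number a weaker inhibitor:

compound 1 `COc1ccc(CCOC(=O)N(c2ccccc2)C2CN3CCC2CC3)cc1` gives 230 nM
compound 2 `O=C(OCCc1ccccc1)N(c1ccccc1)C1CN2CCC1CC2` gives 260 nM
compound 3 `O=C(OCCCc1ccc(F)c(F)c1)N(c1ccccc1)C1CN2CCC1CC2` gives 100 nM

Compound 3 holds the lowest number of the three; the nearest to it is compound 1 a 2.3-fold lower number from compound 1 to compound 3 (0.36 log units; beyond the scatter) and the furthest is compound 2 a 2.6-fold lower number from compound 2 to compound 3 (0.41 log units; beyond the scatter). Between compound 1 and compound 2 the change is a 1.1-fold higher number from compound 1 to compound 2 (0.05 log units; within the scatter).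

Compound 4 `O=C(OCCCc1ccc(Cl)c(Cl)c1)N(c1ccccc1)C1CN2CCC1CC2` differs from compound 3 in one place: 3,4-dichlorophenyl in place of 3,4-difluorophenyl on a saturated chain carbon, three bonds along the chain from an oxygen next to a carbonyl group.

For the measured compounds named here, no measured step in the set swaps one halogen for another on this aromatic ring. The two steps that reach compound 3 both bring in the 3,4-difluorobenzyl in place of an unsubstituted or methoxy-bearing aromatic group, and both are modest in size. They show that this end of the chain is tolerant of a change, but give no direction for exchanging the fluorines for chlorines. The expectation for compound 4 in this assay is therefore a step not clearly beyond the scatter, a 1.3-fold lower number from compound 3 to compound 4 (0.10 log units; within the scatter), with the range widened to allow for either direction. Compound 4 is estimated at 80 nM, between 30 nM and 250 nM.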

Compound 4, inhibition constant: 130 nM
For compound 4 the middle estimate is 1.6-fold (0.21 log units) below the measured one; low and high end bracket the measured number.
By their numbers in this assay, from the lowest: compounds 3, 4, 1 and 2 (each within the scatter of the next, the first and the last beyond it).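

In this assay, the exchange of 3,4-difluorophenyl for 3,4-dichlorophenyl is the first halogen swap shown on this ring at this place on the chain, and it does not separate the two groups (a 1.3-fold higher number from compound 3 to compound 4 (0.11 log units; within the scatter)). Read against the compounds with a phenyl or 4-methoxyphenyl group, the 3,4-dichlorobenzyl group gives a smaller separation than the 3,4-difluorobenzyl group did, with both steps now inside the scatter (a 2.0-fold lower number from compound 2 to compound 4 (0.30 log units; within the scatter); a 1.8-fold lower number from compound 1 to compound 4 (0.25 log units; within the scatter)), so compound 4 cannot be told apart from compound 1, compound 2 or compound 3 in this assay. No evidence in hand bears on the outcome of this halogen exchange.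

The compounds shown leave open how much of the difference between compound 3 and the two shorter-chain compounds belongs to the chain and how much to the halogens, since the 3,4-difluorobenzyl and 3,4-dichlorobenzyl steps change both at once; a plain phenyl on the same chain as compound 3 would divide the two. Also open, going by these compounds, are a single chlorine on the ring, a bromine, a trifluoromethyl or a nitrile in place of these halogens, and a longer chain.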